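Carbamoyl for methoxycarbonyl in the inactive ester series

A few compounds are considered here, and "the series" means these few. Any claim that something is new, unique, unknown or untested is made for them only; others in the source may bear on it.

compound 1 `COC(=O)[C@H]1C[C@@H](c2coc3ccccc3c2=O)N(c2ccccc2)O1` gives > 60000 nM as a limit
compound 2 `CCO[C@H]1C[C@@H](c2coc3cc(Cl)c(Cl)cc3c2=O)N(c2ccccc2)O1` gives 19800 nM as a number
compound 3 `COC(=O)[C@H]1C[C@@H](c2coc3ccc(Cl)cc3c2=O)N(c2ccccc2)O1` gives > 60000 nM as a limit

In a functional assay on A549 cells (Homo sapiens) for inhibition, read by sulforhodamine B assay, with a stated time of 48 h (a higher number here means a weaker inhibitor, a lower number a stronger inhibitor), compound 1 gives > 60000 nM as a limit and not a number. It sits at the limit of > 60000 nM in this assay, at which 2 of the 3 values shown sit, and only compound 2 gives a number. Compound 4 `NC(=O)[C@H]1C[C@@H](c2coc3ccccc3c2=O)N(c2ccccc2)O1` keeps the core of compound 1 and has amino in place of methoxy on a carbonyl carbon, counted as amino in place of methoxy on a carbonyl carbon in full. Within the data shown here, the one measured step is a step that the two limits leave unreadable from compound 1 to compound 3 and it concerns chloro in place of hydrogen on an aromatic carbon, so it gives no size for this change. No direction can be read, and no step beyond the scatter is expected. The expected step is a number no higher from compound 1 to compound 4 (the limit leaves the size open) on this estimate. For compound 4 the estimated value is 60000 nM with an expected range from 22000 nM to 100000 nM around it.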

Compound 4, half-maximal inhibitory concentration: > 60000 nM
Compound 4: a limit, no number; the forecaster's own chance of this, stated with the estimate: 70%; the middle value lies on the limit itself.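

Compound 1 and compound 4 both give only a limit, so no new step can be read between them: the limit of > 60000 nM in this assay, at which 3 of the 4 values shown sit.

The compounds shown leave open whether amino in place of methoxy on a carbonyl carbon changes inhibition in either direction.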